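Pyrimidinone series: carbamate replaced by pyridyl ether

The source may hold more compounds than are shown below. What is called first, only, known or untested is meant among the compounds shown, and "the series" means these compounds.

Measured so far:
- compound 1 `COc1nc(C)c(Nc2nc(Cl)cn([C@H](COC(=O)Nc3ccccc3Cl)C3CC3)c2=O)cc1C`: 1.5 nM
- compound 2 `COc1ccc(NC(=O)OC[C@H](C2CC2)n2cc(Cl)nc(Nc3cc(C)c(OC)nc3C)c2=O)c(C)n1`: 9.2 nM

Among the measured compounds shown here, in an assay on frontal cortex for displacement of a labelled ligand from corticotropin-releasing factor receptor 1 (Rattus norvegicus), with a stated time of 2 h (on this read-out higher numbers stand for weaker inhibition and lower numbers for stronger inhibition), compound 2 gives the higher of the two numbers recorded; the only step available is a 6.1-fold higher number from compound 1 to compound 2 (0.79 log units; beyond the scatter), a change restricted to the group on the amide-type nitrogen of the carbamate.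

Compound 3 `COc1nc(C)c(Nc2nc(Cl)cn([C@H](COc3ccccn3)C3CC3)c2=O)cc1C` differs from compound 2 by pyridin-2-yl in place of (6-methoxy-2-methylpyridin-3-yl)carbamoyl on an oxygen on a saturated carbon. This removes the whole carbamate and leaves a bare aryl ether on the same oxygen. For the measured compounds named here, no measured pair covers a change of this kind; the step from compound 1 to compound 2 shows only that the carbamate end tolerates alteration of its aryl group with a modest shift, and nothing speaks to loss of the carbonyl and the amide hydrogen. Pending data, compound 3 is expected to stay near compound 2, with a 1.3-fold higher number from compound 2 to compound 3 (0.12 log units; within the scatter) judged likely to fall close to or only somewhat beyond the scatter. The estimate for compound 3 in this assay is 12 nM, within 3 nM to 50 nM.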

Compound 3, half-maximal inhibitory concentration: 1.2 nM
The estimate for compound 3 lay 10-fold (1.00 log units) above the measured number, and the stated range ends above it.
By their numbers in this assay, from the lowest: compounds 3 and 1 (each within the scatter of the next); then compound 2.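

In this assay, the carbamate is not required on this oxygen: pyridin-2-yl in its place gives a 7.7-fold lower number from compound 2 to compound 3 (0.88 log units; beyond the scatter), and against the other carbamate it gives a 1.3-fold lower number from compound 1 to compound 3 (0.10 log units; within the scatter). The carbonyl and the amide hydrogen can therefore both go in this pair of steps without a loss of binding, and the bare aryl ether stands level with the 2-chlorophenyl carbamate, not with the 6-methoxy-2-methylpyridin-3-yl carbamate. Nothing at hand bears on the reason for this result.

Open, on these data alone, is whether the ring nitrogen of the pyridin-2-yl group matters, a question a plain phenyl ether would address. Also open, as far as these compounds go, is whether the linking oxygen itself can give way to an amine on the same saturated carbon.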